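Replacing piperidin-1-yl with (4-methoxyphenyl)amino on a shared core

The source may hold more compounds than are shown below. What is called first, only, known or untested is meant among the compounds shown, and "the series" means these compounds.

In a functional assay on HeLa cells (Homo sapiens) for inhibition, read by sulforhodamine B assay (on this read-out higher numbers stand for weaker inhibition and lower numbers for stronger inhibition), three compounds share one core and differ in a single group. Compound 1, `O=C1C(Nc2ccccc2F)=CC(=O)c2c1nc1n2[C@H]2OC[C@@H](O)[C@H]2OC1`, gives 9820 nM. Compound 2, `O=C1C(N2CCCC2)=CC(=O)c2c1nc1n2[C@H]2OC[C@@H](O)[C@H]2OC1`, gives > 16000 nM, which is a limit and not a number. Compound 3, `O=C1C(N2CCCCC2)=CC(=O)c2c1nc1n2[C@H]2OC[C@@H](O)[C@H]2OC1`, gives > 16000 nM, which is also a limit. Compound 3 therefore stands at the limit of > 16000 nM in this assay, at which 2 of the 3 values shown sit, with no exact value known.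

Compound 4, `COc1ccc(NC2=CC(=O)c3c(nc4n3[C@H]3OC[C@@H](O)[C@H]3OC4)C2=O)cc1`, carries (4-methoxyphenyl)amino in place of the piperidin-1-yl of compound 3 on a double-bonded ring carbon: (4-methoxyphenyl)amino in place of piperidin-1-yl on a double-bonded ring carbon. The closest measured guide is the swap in the other direction, an at least 1.6-fold higher number from compound 1 to compound 3 (0.21 log units; that floor lies within the scatter), and the change to pyrrolidin-1-yl reads the same, an at least 1.6-fold higher number from compound 1 to compound 2 (0.21 log units; that floor lies within the scatter). Both are only floors within the scatter, so they are weak evidence, and the remaining comparison gives a step that the two limits leave unreadable from compound 2 to compound 3. Among the compounds with values here, still, compound 1, with its (2-fluorophenyl)amino group, is the only compound here to give a number, 9820 nM. A modest move to a lower number is therefore expected, with the expected step being an at least 1.7-fold lower number from compound 3 to compound 4 (0.24 log units; that floor lies within the scatter). Another limit would not be a surprise. The estimate for compound 4 is 9000 nM, with an expected range from 3500 nM to 20000 nM.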

Compound 4, half-maximal inhibitory concentration: > 8000 nM
Compound 4: a limit, no number (the forecaster's own chance of this, stated with the estimate: 25%); the middle value lies beyond the limit too.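

In this assay compound 4 gives > 8000 nM, which is a limit and not a number, so its steps from compound 1, compound 2 and compound 3 cannot be read. The compounds shown leave open whether (4-methoxyphenyl)amino gives a lower or a higher number than (2-fluorophenyl)amino, piperidin-1-yl or pyrrolidin-1-yl on the shared core.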